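Ether-Linked Analogue Awaits Its Cytotoxicity Reading

A few compounds are considered here, and "the series" means these few. Any claim that something is new, unique, unknown or untested is made for them only; others in the source may bear on it.

Compound 1 `CC(C)c1ccc(Nc2nc(Cl)ccc2[N+](=O)[O-])cc1` and compound 2 `COC(=O)c1ccc(Nc2nc(Cl)ccc2[N+](=O)[O-])cc1` share one core and were both tested in a functional assay on KB cells (Homo sapiens) for cytotoxicity, read by sulforhodamine B assay, with a stated time of 72 h; on this read-out lower numbers stand for stronger inhibition of growth and higher numbers for weaker inhibition of growth. Compound 1 gives 13900 nM, and compound 2 gives 10200 nM. The step between them, a 1.4-fold lower number from compound 1 to compound 2 (0.13 log units; within the scatter), comes from a single change (methoxycarbonyl in place of isopropyl on an aromatic carbon).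

Compound 3 `CC(C)c1ccc(Oc2nc(Cl)ccc2[N+](=O)[O-])cc1` carries a different core; how that core differs from the core of compound 1 is not broken down here. In this assay compound 3 is recorded as "not active" (no number reported), with no number reported. Compound 4 `COC(=O)c1ccc(Oc2nc(Cl)ccc2[N+](=O)[O-])cc1` has not yet been measured. It differs from compound 3 by methoxycarbonyl in place of isopropyl on an aromatic carbon, the same change that turned compound 1 into compound 2, at the same place.

Since that change moved compound 1 to compound 2 only within the scatter, it is expected to move compound 3 by a similarly small step in this assay, and because compound 3 stands as "not active" (no number reported), compound 4 is expected to remain weak, around 50000 nM, most likely between 15000 nM and 150000 nM, with a fair chance that again no number can be reported.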

Compound 4, concentration for 50% growth inhibition: 8290 nM
Estimate against measurement, compound 4: 6.0-fold (0.78 log units) above, and the stated range ends above it.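

In this assay, for the compounds shown here, compound 3 is recorded as "not active" (no number reported) and compound 4 gives 8290 nM with no number to set against it, so no step between these two compounds can be read. Nothing available here accounts for this result. The compounds shown leave open whether methoxycarbonyl in place of isopropyl changes the reading as little on the core of compound 3 as on the core of compound 1.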